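The source may hold more compounds than are shown below. What is called first, only, known or untested is meant among the compounds shown, and "the series" means these compounds.

Measured so far in a functional assay on ECa-109 cells (Homo sapiens) for inhibition, read by MTT assay, with a stated time of 72 h; on this read-out lower numbers stand for stronger inhibition and higher numbers for weaker inhibition:
Compound 1 `CC(C)c1ccc(-c2nc(SCc3cn(CC(=O)NC(=O)Nc4ccccn4)nn3)nc(Nc3ccc(Cl)cc3)c2C#N)cc1`: 11200 nM
Compound 3 `COc1cc(-c2nc(SCc3cn(CC(=O)NC(=O)Nc4ccccn4)nn3)nc(Nc3ccc(C)cc3)c2C#N)cc(OC)c1OC`: 21300 nM
Compound 2 `COc1cc(-c2nc(SCc3cn(CC(=O)NC(=O)Nc4ccccn4)nn3)nc(Nc3ccc(C(C)C)cc3)c2C#N)cc(OC)c1OC` gives only a limit in this assay, > 64000 nM.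

Compound 3 has the highest of the two numbers shown; the nearest is compound 1, whose number is lower, but the gap between them lies within the scatter, so no order between the two can be read from it. Among the compounds with values here, the one step that is known, an at least 3.0-fold lower number from compound 2 to compound 3 (0.47 log units; beyond the scatter), can be given only as a lower bound because the value of compound 2 is a limit (the limit of > 64000 nM in this assay, at which 1 of the 3 values shown sits).

Compound 4 `COc1cc(-c2nc(SCc3cn(CC(=O)NC(=O)Nc4ccccn4)nn3)nc(Nc3ccc(Cl)cc3)c2C#N)cc(OC)c1OC` differs from compound 3 by chloro in place of methyl on an aromatic carbon. Within the data shown here, no step in the set exchanges methyl for chloro directly, so the expectation rests on two pieces: compound 1, which carries the same chloro group and gives 11200 nM, and the step from the larger isopropyl to methyl, which brought the number down. Chloro is a single heavy atom in this position, as methyl is, and it is expected that compound 4 lands near compound 3 or somewhat lower, with the step of a 1.5-fold lower number from compound 3 to compound 4 (0.18 log units; within the scatter) estimated to stay close to the scatter. Compound 4 is therefore estimated at 14000 nM, with a range from 5000 nM to 40000 nM.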

Compound 4, half-maximal inhibitory concentration: > 64000 nM
Compound 4: a limit, no number; the forecaster's own chance of this, stated with the estimate: 10%; at least 4.5-fold (0.66 log units) between middle value and limit.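

Exchanging one heavy atom for another at this carbon is not a neutral change in this assay: chloro in place of methyl gives an at least 3.0-fold higher number from compound 3 to compound 4 (0.47 log units; beyond the scatter). Within the data shown here, with the 3,4,5-trimethoxyphenyl group in place, the (4-methylphenyl)amino compound is thus the only one of compounds 2, 3 and 4 that gives a number, and the count of heavy atoms in the group does not sort them, since chloro and methyl each have one. The chloro group alone does not decide the outcome either, as 3,4,5-trimethoxyphenyl in place of 4-isopropylphenyl, with chloro kept, gives an at least 5.7-fold higher number from compound 1 to compound 4 (0.75 log units; beyond the scatter); compound 2 and compound 4 both stand at a limit, and the step between them cannot be read: the limit of > 64000 nM in this assay, at which 2 of the 4 values shown sit.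

The compounds shown leave open whether a fluoro, a methoxy or an ethyl group on this carbon would give a number alongside the 3,4,5-trimethoxyphenyl group. They also leave open whether methyl is a narrow exception in that series, and whether the (4-methylphenyl)amino group would change the number with 4-isopropylphenyl in the core.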